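The compounds below may be only part of what the source reports. "The series", "measured", "known", "first", "only" and "open" are said of these compounds alone.

Measured so far in a functional assay on Molt4/C8 cells (Homo sapiens) for inhibition; on this read-out higher numbers stand for weaker inhibition and lower numbers for stronger inhibition:
- compound 1, `O=C1/C(=C/c2ccccc2Cl)Cc2ccccc21`: 128000 nM
- compound 2, `O=C1/C(=C/c2ccccc2Br)CCCc2ccccc21`: 38400 nM

Compound 2 holds the lowest of the two numbers; compound 1 sits higher, and that gap is beyond the scatter, so on the numbers shown compound 2 is the stronger inhibitor of the pair. Going by the values given here, no step between compounds that differ in one place is available, so nothing here shows how a single halogen exchange on this aromatic ring moves the read-out.

Compound 3, `O=C1/C(=C/c2ccccc2F)CCCc2ccccc21`, has not yet been measured. It is compound 2 with fluoro in place of bromo on an aromatic carbon. Among the compounds with values here, with no comparable step to lean on, the expectation rests on the size of the exchange alone: a heavy bromine replaced by a small fluorine, with no change in rings, donors, acceptors or charge. The expected direction is toward a weaker inhibitor than compound 2, by a step of moderate size that may or may not clear the scatter, as a 2.1-fold higher number from compound 2 to compound 3 (0.32 log units; beyond the scatter) expresses. Compound 3 is therefore estimated at 80000 nM, within a range from 30000 nM to 250000 nM.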

Compound 3, half-maximal inhibitory concentration in the Molt4/C8 assay: 42100 nM
Compound 3: the middle estimate sits 1.9-fold (0.28 log units) above what was measured, and the stated range covers the measured number.
By their numbers in the Molt4/C8 assay, from the lowest: compounds 2 and 3 (each within the scatter of the next); then compound 1.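

Going by these compounds alone, in the Molt4/C8 assay the first single-place step, fluoro in place of bromo on an aromatic carbon ortho to a large group, is a 1.1-fold higher number from compound 2 to compound 3 (0.04 log units; within the scatter), so this exchange leaves no readable mark on inhibition. In a physicochemical assay for lipophilicity (a higher number here means a more lipophilic compound, a lower number a more polar compound), compound 2 gives 5.04 and compound 3 gives 4.55. In the physicochemical assay the same exchange is a number 0.49 log units lower from compound 2 to compound 3 (beyond the scatter), so the pair separates clearly on that read-out while staying together on inhibition. For this one pair, then, inhibition does not follow the measured partition coefficient: the measured partition coefficient of compound 2, 5.04, and of compound 3, 4.55, a number 0.49 log units lower (beyond the scatter)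

Within the data shown here, whether the position stays this undemanding for a group of another kind, such as methoxy, an amine or a carboxylic acid, remains open, since bromo and fluoro are the only two groups compared there on the shared core. On these data alone, compound 1 differs from compound 2 and compound 3 in more than one place, so what its core contributes to inhibition also remains open.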